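The source may report more compounds than this note shows. Statements on the series, on what has been measured and on what is new or still open speak of the compounds shown alone.

In a study of antiproliferative agents, three quinolone-type compounds were tested in a functional assay on BGC-823 cells (Homo sapiens) for antiproliferative activity, read by MTT assay, with a stated time of 48 h; a lower number here means a stronger inhibitor, a higher number a weaker inhibitor. Compound 1 `CCn1cc(-c2cccc(F)c2)c(=O)c2cc(F)c(N3CCNCC3)cc21` gives 27300 nM in this assay. Compound 2 `CCn1cc(-c2cccc(Cl)c2)c(=O)c2cc(F)c(N3CCNCC3)cc21` differs from compound 1 by chloro in place of fluoro on an aromatic carbon, and in this assay compound 2 gives 18400 nM. That change brought a 1.5-fold lower number from compound 1 to compound 2 (0.17 log units; within the scatter).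

Compound 3 `O=c1c(-c2ccc(F)cc2)cn(C2CC2)c2cc(N3CCNCC3)c(F)cc12` rests on a different core; the difference between the two cores is not broken down here. In this assay compound 3 gives 15100 nM, a number that sits within the scatter of both compound 1 and compound 2, so no order among the three can be drawn.

Compound 4 `O=c1c(-c2ccc(Cl)cc2)cn(C2CC2)c2cc(N3CCNCC3)c(F)cc12` has not yet been measured. It differs from compound 3 by chloro in place of fluoro on an aromatic carbon. Among the compounds with values here, this is the same kind of change as the one from compound 1 to compound 2, but not the same: in the earlier pair the halogen stands meta to a large group, whereas in compound 3 and compound 4 it stands para to a large group. With only the earlier step of a 1.5-fold lower number from compound 1 to compound 2 (0.17 log units; within the scatter) as a guide, the change in this assay is expected to amount to a 1.4-fold lower number from compound 3 to compound 4 (0.14 log units; within the scatter). Compound 4 is therefore estimated to give 11000 nM in this assay, with a likely range from 4500 nM to 28000 nM.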

Compound 4, half-maximal inhibitory concentration: 12900 nM
The estimate for compound 4 lay 1.2-fold (0.07 log units) below the measured number; measured number inside the range.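

Replacing the 4-fluorophenyl of compound 3 with the 4-chlorophenyl of compound 4 gives a 1.2-fold lower number from compound 3 to compound 4 (0.07 log units; within the scatter). Set beside the earlier step, chloro in place of fluoro on an aromatic carbon gives results that cannot be told apart on the two cores in this assay: the same change on two cores in this assay, a 1.5-fold lower number (0.17 log units; within the scatter) from compound 1 to compound 2 and a 1.2-fold lower number (0.07 log units; within the scatter) from compound 3 to compound 4, 1.3-fold (0.10 log units) apart, within the scatter of two such steps

This agreement shows only that nothing in these two pairs separates the steps on the two cores; since each step lies within the scatter, it does not show that chloro in place of fluoro has a real effect on either core, and two pairs whose halogens also stand in different places cannot establish a rule for the series.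

The compounds shown leave open whether any other group on this aromatic ring, such as bromo, methoxy, trifluoromethyl or an amine, would give a step beyond the scatter in this assay. They also leave open whether a carboxylic acid on the core, or a longer chain on its ring nitrogen, would give a number that can be distinguished from those of these four compounds.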